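The compounds below may be only part of what the source reports. "The series", "measured", "known", "first", "only" and "open" are said of these compounds alone.

Measured compounds and their numbers in a functional assay on PANC-1 cells (Homo sapiens) for inhibition, read by MTT assay, with a stated time of 24 h, tested at 10 uM; a lower number here means less inhibition, a higher number more inhibition at the concentration tested (going by the name of the read-out):
compound 1 `CC(C)=CCC1Cc2c(OCCCNC(=O)c3ccco3)cc(=O)n(CCCO)c2CC1(C)C`: 4.3%
compound 2 `CC(C)=CCC/C(C)=C/CC1Cc2c(OCCCNS(=O)(=O)c3ccc(Cl)cc3)cc(=O)n(CCCO)c2CC1(C)C`: 16.1%
compound 3 `CC(C)=CCC/C(C)=C/CC1Cc2c(OCCCNC(=O)c3ccco3)cc(=O)n(CCCO)c2CC1(C)C`: 2.8%

Compound 3 holds the lowest of the three numbers. Its nearest neighbour is reached by the step of a number 1.5 percentage points lower from compound 1 to compound 3 (within the scatter), which stays within the scatter, so no order can be read between those two. Among the measured compounds shown here, the only step beyond the scatter is a number 13.3 percentage points lower from compound 2 to compound 3 (beyond the scatter).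

Compound 4 `CC(C)=CCC/C(C)=C/CC1Cc2c(OC(=O)Nc3ccc(Cl)cc3)cc(=O)n(CCCO)c2CC1(C)C` is not yet measured. It differs from compound 3 as follows: (4-chlorophenyl)carbamoyl in place of 3-(((furan-2-yl)carbonyl)amino)propyl on an oxygen on an aromatic ring.

The step that bears on this change is a number 13.3 percentage points lower from compound 2 to compound 3 (beyond the scatter), where a (furan-2-yl)carbonyl replaced a (4-chlorophenyl)sulfonyl on an amine nitrogen. For the measured compounds named here, compound 4 brings a 4-chlorophenyl group back, but as a carbamoyl directly on the ring oxygen, with the propyl chain gone; no measured pair covers that part of the change. The step of a number 1.5 percentage points lower from compound 1 to compound 3 (within the scatter) concerns the chain and has no bearing here. Going by these compounds, a modest rise in this assay is therefore expected for compound 4, partly reversing the drop seen in the sulfonyl-to-carbonyl step, with a wide range as the linker change itself is untested. The estimate for compound 4 is 10%, between 0% and 25%, an expected step of a number 7.2 percentage points higher from compound 3 to compound 4 (within the scatter).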

Compound 4, a percentage reported as inhibition, at one concentration (the size of the read-out at that concentration, not a potency): 4.3%
Compound 4: middle estimate off by 5.7 percentage points, on the high side; measured number inside the range.
By their numbers in this assay, from the lowest: compounds 3, 1 and 4 (each within the scatter of the next); then compound 2.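

In this assay, the oxygen on an aromatic ring is now varied directly: (4-chlorophenyl)carbamoyl in place of 3-(((furan-2-yl)carbonyl)amino)propyl gives a number 1.5 percentage points higher from compound 3 to compound 4 (within the scatter), so no order can be read between these two substituents, despite the change of ring and linker. The presence of a 4-chlorophenyl group does not by itself give a number like that of compound 2: compound 4 gives 4.3%, and compound 2, which carries that group as a sulfonamide on the propoxy chain, gives 16.1%. Nothing available explains this result.

Still open, going by these compounds, is whether a basic amine or a carboxylic acid at the end of the propoxy chain, or a longer chain on the same oxygen, would move the number beyond the scatter. On these data alone, it is also open whether the (4-chlorophenyl)sulfonyl group keeps its number on the shorter 3-methylbut-2-en-1-yl side chain of compound 1, and whether an unsubstituted phenyl ring in the carbamoyl group would read the same as compound 4.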